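Shortening the Chain: Estimating Cytotoxicity of Compound 3

The source may hold more compounds than are shown below. What is called first, only, known or untested is meant among the compounds shown, and "the series" means these compounds.

Measured so far:
compound 1, `CCCCCCC1C(=O)N(O)C(=O)c2ccccc21`, 4400 nM
compound 2, `CCCCCCc1c(O)n(O)c(=O)c2ccccc12`, 128000 nM

In an ADME assay on MT4 cells (Homo sapiens) for cytotoxicity, read by MTT assay (a lower number here means that less compound is tolerated, a higher number that more compound is tolerated), compound 1 stands at the lowest of these two numbers, and compound 2 stands far higher, beyond the usual scatter. Compound 3, `CC1C(=O)N(O)C(=O)c2ccccc21`, is not yet measured. It differs from compound 1 in one place: hydrogen in place of pentyl on a saturated chain carbon bound to a saturated ring carbon. Among the measured compounds shown here, no measured pair shows such a change, so the size of the step is uncertain; the expectation is a moderate rise in tolerated concentration, with the step of an 11-fold higher number from compound 1 to compound 3 (1.06 log units; beyond the scatter) estimated as clearly beyond the scatter. Compound 3 is expected to give 50000 nM, within 12000 nM to 200000 nM.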

Compound 3, half-maximal cytotoxic concentration: 250000 nM
Compound 3: middle estimate off by 5.0-fold (0.70 log units), on the low side; the measured number lies above the stated range.
By their numbers in this assay, from the lowest: compound 1; then compounds 2 and 3 (each within the scatter of the next).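

In this assay, hydrogen in place of pentyl on a saturated chain carbon bound to a saturated ring carbon gives a 57-fold higher number from compound 1 to compound 3 (1.75 log units; beyond the scatter) and so counts as a large step. This position is therefore far from indifferent to what sits on it: the change from hexyl to methyl greatly raises the concentration the cells tolerate. Nothing measured here gives a reason for the size of this step. Still open, as far as these compounds go, is whether the tolerated concentration rises evenly as the chain shortens, which a propyl chain at this place could show, and how an amine or a carboxylic acid on the chain would compare.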